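The source may hold more compounds than are shown below. What is called first, only, known or untested is meant among the compounds shown, and "the series" means these compounds.

Measured compounds:
Compound 1, `Cn1c(=O)c(S(=O)(=O)c2ccc(Cl)cc2)cc2cnc(Nc3cccc4[nH]ccc34)nc21`: 5000 nM
Compound 2, `Cn1c(=O)c(S(=O)(=O)c2ccc(Cl)cc2)cc2cnc(Nc3cnc4[nH]ccc4c3)nc21`: 5000 nM
Compound 3, `Cn1c(=O)c(S(=O)(=O)c2ccc(F)cc2)cc2cnc(Nc3cccc4[nH]ccc34)nc21`: 750 nM

All three were tested in a functional assay on K562 cells (Homo sapiens) for inhibition, read by trypan blue exclusion, with a stated time of 72 h; a higher number here means a weaker inhibitor, a lower number a stronger inhibitor. Compound 1 and compound 2 differ by a group of 9 heavy atoms (7 carbon, 2 nitrogen; one five-membered aromatic ring with 1 hetero atom, one six-membered aromatic ring with 1 hetero atom) in place of a group of 9 heavy atoms (8 carbon, 1 nitrogen; one five-membered aromatic ring with 1 hetero atom, one six-membered aromatic ring of carbon only), on a nitrogen on an aromatic ring, and this change gave no change at the digits printed from compound 1 to compound 2 (within the scatter). Compound 1 and compound 3 differ by fluoro in place of chloro on an aromatic carbon, which gave a 6.7-fold lower number from compound 1 to compound 3 (0.82 log units; beyond the scatter); compound 3 stands lowest of the three, with both steps to it beyond the scatter.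

Compound 4, `Cn1c(=O)c(S(=O)(=O)c2ccc(F)cc2)cc2cnc(Nc3cnc4[nH]ccc4c3)nc21`, has not yet been measured. It differs from compound 3 by a group of 9 heavy atoms (7 carbon, 2 nitrogen; one five-membered aromatic ring with 1 hetero atom, one six-membered aromatic ring with 1 hetero atom) in place of a group of 9 heavy atoms (8 carbon, 1 nitrogen; one five-membered aromatic ring with 1 hetero atom, one six-membered aromatic ring of carbon only), on a nitrogen on an aromatic ring, the same change that was made from compound 1 to compound 2, at a place that is described in the same words in both pairs. The two cores differ by fluoro in place of chloro on an aromatic carbon.

Because the earlier step was no change at the digits printed from compound 1 to compound 2 (within the scatter), the expected step from compound 3 to compound 4 is a 1.1-fold higher number from compound 3 to compound 4 (0.03 log units; within the scatter), leaving compound 4 near compound 3. Compound 4 is thus estimated at 800 nM, expected to lie between 300 nM and 2500 nM.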

Compound 4, half-maximal inhibitory concentration: 750 nM
Compound 4: the middle estimate sits 1.1-fold (0.03 log units) above what was measured; the measured number falls inside the stated range.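

In this assay, exchanging the 1H-indol-4-yl group for the group carrying a second ring nitrogen gave no change at the digits printed from compound 3 to compound 4 (within the scatter), while fluoro in place of chloro gave a 6.7-fold lower number from compound 2 to compound 4 (0.82 log units; beyond the scatter). The exchange of the ring group therefore read the same on the chloro and the fluoro cores: the same change on two cores in this assay, no change at the digits printed (within the scatter) from compound 1 to compound 2 and no change at the digits printed (within the scatter) from compound 3 to compound 4, 1.0-fold (0.00 log units) apart, within the scatter of two such steps. The halogen exchange also carried over, but this four-compound square shows agreement for these two changes only, and it does not show why they behave this way or that they would do so on any other core: the same change on two cores in this assay, a 6.7-fold lower number (0.82 log units; beyond the scatter) from compound 1 to compound 3 and a 6.7-fold lower number (0.82 log units; beyond the scatter) from compound 2 to compound 4, 1.0-fold (0.00 log units) apart, within the scatter of two such steps.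

The compounds shown leave open how a methoxy or trifluoromethyl group would behave in place of the fluoro or chloro. They also leave open whether a plain phenyl or a pyridine on the same aromatic-ring nitrogen would follow the same pattern.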